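Notes on compound 4 against compounds 1 to 3

A few compounds are considered here, and "the series" means these few. Any claim that something is new, unique, unknown or untested is made for them only; others in the source may bear on it.

Compound 1 `CC(C)[C@H](C[C@H]1OC(=O)NC1=O)c1ccc(-c2ccc3cccc(F)c3c2)[nH]c1=O` gives 1.68 h in an ADME assay on microsomes from liver (Homo sapiens) for metabolic stability; a higher number here means that the compound lasts longer, a lower number that the compound disappears faster. Of the two plain numbers in this assay, compound 1 has the lowest; the nearest is compound 2 `O=C1NC(=O)/C(=C/C(c2ccc(-c3ccc4cccc(F)c4c3)[nH]c2=O)C2CC2)O1`, which gives 1.98 h, a gap within the scatter. Compound 3 `CCC(CC)C(/C=C1\OC(=O)NC1=O)c1ccc(-c2ccc3cccc(F)c3c2)[nH]c1=O` reaches only the limit of this assay, > 3 h, so it is not a number (the limit of > 3 h in this assay, at which 1 of the 3 values shown sits). Going by the values given here, the single measured step, an at least 1.5-fold higher number from compound 2 to compound 3 (0.18 log units; that floor lies within the scatter), concerns pentan-3-yl in place of cyclopropyl and sits at its floor within the scatter.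

Compound 4 `CC(C)[C@@H](c1ccc(-c2ccc3cccc(F)c3c2)[nH]c1=O)[C@H]1OC(=O)NC1=O` differs from compound 1 by 2,4-dioxo-1,3-oxazolidin-5-yl in place of (2,4-dioxo-1,3-oxazolidin-5-yl)methyl on a saturated chain carbon bound to an aromatic carbon and a saturated chain carbon. Among the compounds with values here, no measured step alters this part of the structure; the one step known touches a different group and is itself within the scatter. The series therefore offers no ground for a change beyond the scatter in this assay, and a 1.1-fold higher number from compound 1 to compound 4 (0.03 log units; within the scatter) is the expected step. Compound 4 is accordingly estimated at 1.8 h, with a range from 0.9 h to 3.6 h.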

Compound 4, half-life: > 3 h
Compound 4 ended at the assay's limit; the forecaster's own chance of this, stated with the estimate: 15%; middle value at least 1.6-fold (0.22 log units) from the limit.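

In this assay compound 4 gives > 3 h, which is a limit and not a number: the limit of > 3 h in this assay, at which 2 of the 4 values shown sit.

Going by these compounds alone, this is the first measured step on this part of the structure: 2,4-dioxo-1,3-oxazolidin-5-yl in place of (2,4-dioxo-1,3-oxazolidin-5-yl)methyl gives an at least 1.7-fold higher number from compound 1 to compound 4 (0.25 log units; that floor lies within the scatter). On these data alone, the true size of the step stays open, since it may exceed its floor but cannot be read as a change beyond the scatter.

The compounds shown leave open how far compound 4 lies past the limit, and whether the same step would hold with cyclopropyl or pentan-3-yl in the structure. Also open, as far as these compounds go, is how an amine or a carboxylic acid in place of 2,4-dioxo-1,3-oxazolidin-5-yl would behave in this assay.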